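Swapping halogens for methyls on an aryl-quinolinone antagonist

The source may hold more compounds than are shown below. What is called first, only, known or untested is meant among the compounds shown, and "the series" means these compounds.

Measured compounds:
Compound 1 `O=C(Nc1cc2c(OCCC3CCCCN3)c(-c3ccc(Cl)c(Cl)c3)c(O)nc2cc1Cl)NC1CC1` – 18 nM
Compound 2 `O=[N+]([O-])c1cc2c(OCCC3CCCCN3)c(-c3cccc(F)c3)c(O)nc2cc1Cl` – 53 nM

In a functional assay on cells (Pituitary gland cell) for antagonist activity at Gonadotropin-releasing hormone receptor (Rattus norvegicus) (a higher number here means a weaker inhibitor, a lower number a stronger inhibitor), compound 1 gives 18 nM, the lower of the two numbers; in this assay compound 2 gives 53 nM, a gap beyond the scatter. Compound 3 `Cc1ccc(-c2c(O)nc3cc(Cl)c(NC(=O)NC4CC4)cc3c2OCCC2CCCCN2)cc1C` keeps the shared core of compound 1 and changes one group: 3,4-dimethylphenyl in place of 3,4-dichlorophenyl on an aromatic carbon. Among the measured compounds shown here, no measured pair shows this change, so the step from compound 1 to compound 3 is expected to be small, in this assay a 1.7-fold higher number from compound 1 to compound 3 (0.22 log units; within the scatter), with a slight weakening more likely than a gain. Compound 3 is therefore estimated at 30 nM, within 8 nM to 120 nM.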

Compound 3, half-maximal inhibitory concentration: 6 nM
Estimate against measurement, compound 3: 5.0-fold (0.70 log units) above, and the stated range ends above it.
By their numbers in this assay, from the lowest: compound 3; then compound 1; then compound 2.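

On the aromatic carbon ortho to the 2-(piperidin-2-yl)ethoxy group, 3,4-dimethylphenyl in place of 3,4-dichlorophenyl gives a 3.0-fold lower number from compound 1 to compound 3 (0.48 log units; beyond the scatter) in this assay, a gain beyond the scatter. The two chlorine atoms are therefore not needed for activity at this position, since the all-carbon ring with the same heavy-atom count gives the lower number. Nothing measured here accounts for this gain. On these data alone, whether a single methyl, an ethyl or a methoxy group would serve on this phenyl ring stays open, as does whether the swap would give a similar step on another core.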